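Aryloxy Side-Chain Changes on a Shared Core

The source may report more compounds than this note shows. Statements on the series, on what has been measured and on what is new or still open speak of the compounds shown alone.

Compound 1, `O=C(O)c1csc([C@H]2CC[C@@H]3[C@@H](COc4ccc(C(F)(F)F)cc4)[C@H](O)C[C@@H]3O2)n1`, in an assay on HEK293 cells for agonist activity at prostaglandin E2 receptor EP2 subtype (Homo sapiens), read by a beta-galactosidase reporter and beta-arrestin recruitment, with a stated time of 90 min (a higher number here means that more compound is needed for the effect, a lower number that less compound is needed), gives > 10000 nM, which is a limit of the assay.
Compound 2, `O=C(O)c1csc([C@H]2CC[C@@H]3[C@@H](COc4ccc(F)cc4)[C@H](O)C[C@@H]3O2)n1`, in this assay gives > 10000 nM, which is again a limit of the assay.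
Compound 3, `O=C(O)c1csc([C@H]2CC[C@@H]3[C@@H](CCCOc4ccccc4)[C@H](O)C[C@@H]3O2)n1`, in this assay gives > 10000 nM, which is also a limit of the assay.

Compound 3 thus stands only at a limit in this assay, and the two further values shown are limits as well, so that all three sit at the limit of > 10000 nM in this assay, at which 3 of the 3 values shown sit. The steps a step that the two limits leave unreadable from compound 1 to compound 2 and a step that the two limits leave unreadable from compound 2 to compound 3 therefore cannot be sized. Compound 4, `O=C(O)c1csc([C@H]2CC[C@@H]3[C@@H](COc4ccccc4Cl)[C@H](O)C[C@@H]3O2)n1`, differs from compound 3 by 2-chlorophenoxy in place of 2-phenoxyethyl on a saturated chain carbon bound to a saturated ring carbon. Both measured steps bear on the same side chain yet give no readable size, so no step beyond the scatter can be projected in this assay in either direction; the nearest expectation is that compound 4 stays at the limit. Compound 4 is accordingly estimated at 30000 nM, with a range from 10000 nM to 100000 nM. The expected step that the limit leaves unreadable from compound 3 to compound 4 carries little weight, resting as it does on limits alone.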

Compound 4, half-maximal effective concentration: 203 nM
Beside the measured number, compound 4's estimate is 150-fold (2.17 log units) above it; measured number outside the range, below it.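

At this saturated chain carbon bound to a saturated ring carbon, the side chain can decide whether this assay gives a readable number at all: 2-chlorophenoxy in place of 2-phenoxyethyl produces an at least 49-fold lower number from compound 3 to compound 4 (1.69 log units; beyond the scatter). With the ether oxygen kept, 2-chlorophenyl in place of 4-fluorophenyl gives an at least 49-fold lower number from compound 2 to compound 4 (1.69 log units; beyond the scatter), and 2-chlorophenyl in place of 4-(trifluoromethyl)phenyl gives an at least 49-fold lower number from compound 1 to compound 4 (1.69 log units; beyond the scatter), so these steps are large, whereas the steps among compounds 1, 2 and 3 cannot be read. Only compound 4 comes off the limit, and the other three remain there: the limit of > 10000 nM in this assay, at which 3 of the 4 values shown sit.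

The compounds shown do not separate the contribution of the chlorine from that of the rest of the 2-chlorophenyl group. From the compounds shown here alone, it remains open how a plain phenoxy group, or a bromine or a methyl group in place of the chlorine, would behave on the shared core.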